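A few compounds are considered here, and "the series" means these few. Any claim that something is new, unique, unknown or untested is made for them only; others in the source may bear on it.

Measured in a physicochemical assay for solubility, with a stated time of 24 h, tested at 30 mg/mL; on this read-out lower numbers stand for lower solubility and higher numbers for higher solubility:
compound 1 `Cc1cc(COc2ccc(S(=O)(=O)NC(C)(C)CC(=O)NO)cc2)c2ccccc2n1`: 1600000 nM
compound 2 `Cc1cc(COc2ccc(S(=O)(=O)NC3(CC(=O)NO)COC3)cc2)c2ccccc2n1`: 200000 nM
compound 3 `Cc1cc(COc2ccc(S(=O)(=O)NCC(=O)NO)cc2)c2ccccc2n1`: 100000 nM

Compound 3, at 100000 nM, sits at the low end of this short series alongside compound 2, and the gap between them is small: a 2.0-fold lower number from compound 2 to compound 3 (0.30 log units; within the scatter). Compound 1 stands well apart from both, with a 16-fold lower number from compound 1 to compound 3 (1.20 log units; beyond the scatter) and an 8.0-fold lower number from compound 1 to compound 2 (0.90 log units; beyond the scatter).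

The next change gives compound 4 `Cc1cc(COc2ccc(S(=O)(=O)NC3(C(=O)NO)CC3)cc2)c2ccccc2n1`. The core stays the same, and the difference is a group of 7 heavy atoms (4 carbon, 1 nitrogen, 2 oxygen; one three-membered non-aromatic ring of carbon only) in place of a group of 5 heavy atoms (2 carbon, 1 nitrogen, 2 oxygen; no ring), on a sulfonamide nitrogen.

All three measured steps involve the same place on the sulfonamide nitrogen, so all bear on this change, though none matches it exactly. Going by the values given here, compound 2, the only measured compound with a ring in this group, stands at 200000 nM. With a larger group than compound 3 but no ring, compound 1 stands at 1600000 nM. Among the compounds with values here, with only three compounds, the data show no rule for ring size or group size. They give some support for a modest rise from compound 3 and little support for a large one, since only compound 1 stands clearly apart. The expected change is a 2.0-fold higher number from compound 3 to compound 4 (0.30 log units; within the scatter). The estimated value for compound 4 is 200000 nM. The expected range for compound 4 runs from 60000 nM to 800000 nM.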

Compound 4, solubility: 46000000 nM
Compound 4: middle estimate off by 230-fold (2.36 log units), on the low side; the whole stated range lies below it.
By their numbers in this assay, from the lowest: compounds 3 and 2 (each within the scatter of the next); then compound 1; then compound 4.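

In this assay, the group on the sulfonamide nitrogen turns out to span a far wider range than compounds 1 to 3 suggested, since the group with the three-membered ring of carbon only gives a very large step up (a 460-fold higher number from compound 3 to compound 4 (2.66 log units; beyond the scatter)). Two groups that both hold a ring also read very differently at this place (a 230-fold higher number from compound 2 to compound 4 (2.36 log units; beyond the scatter)), so the presence of a ring alone does not set the number, and compound 4 also passes the earlier high point (a 29-fold higher number from compound 1 to compound 4 (1.46 log units; beyond the scatter)), although its group of 7 heavy atoms is smaller than the groups of compound 1 and compound 2, which means group size does not order these four compounds either. Nothing measured here offers an explanation for this step.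

The compounds shown leave open whether the three-membered ring itself goes with the high number, a question that a four-membered ring of carbon only, or two methyl groups in place of the ring, would help to settle. They also leave open whether the high number persists when a carboxylic acid replaces the hydroxycarbamoyl part of the group on this same core.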